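Trading trifluoromethyl for hydrogen on a shared core

The source may hold more compounds than are shown below. What is called first, only, known or untested is meant among the compounds shown, and "the series" means these compounds.

Within the data shown here, in an ADME assay on MDCK cells (Canis lupus familiaris) for cytotoxicity (a lower number here means that less compound is tolerated, a higher number that more compound is tolerated), compound 1 `O=[N+]([O-])C1=CNc2nc(C(F)(F)F)nn2C1c1ccc(O)c(O)c1` gives 1210000 nM, the only exact number available so far. Compound 2 `O=[N+]([O-])C1=NNc2ncnn2C1c1ccc(O)c(O)c1` reports > 1630000 nM, and this value is a limit of the assay, not a number. On these data alone, the exact position of compound 1 relative to compound 2 therefore stays open.

The next compound to test is compound 3 `O=[N+]([O-])C1=CNc2ncnn2C1c1ccc(O)c(O)c1`, which keeps the core of compound 1 and changes one place: hydrogen in place of trifluoromethyl on an aromatic carbon. In plain terms, this is hydrogen in place of trifluoromethyl on an aromatic carbon.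

Among the measured compounds shown here, no measured pair isolates this change, so any expectation is rough. For the measured compounds named here, the only hint comes from compound 2, which also carries hydrogen on that carbon, although it differs elsewhere, and which again shows the limit > 1630000 nM. A small move toward a higher number in this assay is therefore expected, possibly no larger than the usual scatter, and the estimated step is a 1.3-fold higher number from compound 1 to compound 3 (0.11 log units; within the scatter). The estimate for compound 3 is 1550000 nM, with an expected range from 800000 nM to 2600000 nM.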

Compound 3, half-maximal cytotoxic concentration: 368000 nM
Compound 3: middle estimate off by 4.2-fold (0.62 log units), on the high side; measured number outside the range, below it.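

On the shared core, the aromatic carbon between two ring nitrogen atoms turns out to be a place where the group matters in this assay: hydrogen in place of trifluoromethyl gives a 3.3-fold lower number from compound 1 to compound 3 (0.52 log units; beyond the scatter). Among these compounds, this is the first measured step in the set, and it lies beyond the usual scatter, so for this one pair the direction is clear: less compound is tolerated with hydrogen on this carbon than with trifluoromethyl. Compound 2 still offers only a limit of the assay and not a number, so no step involving it can be read: the limit of > 1630000 nM in this assay, at which 1 of the 3 values shown sits.

One pair cannot show why the number moves, nor whether the same step would hold on the core of compound 2. A methyl group, a chlorine atom or an amine on the same aromatic carbon would show whether the higher number belongs to trifluoromethyl alone or whether other groups at this place also separate from hydrogen in this assay.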